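Swapping an Aryl Group: Estimating Compound 4

The source may report more compounds than this note shows. Statements on the series, on what has been measured and on what is new or still open speak of the compounds shown alone.

Three compounds have been measured in a functional assay on the whole organism (strain Wistar albino) for inhibition, with Rattus norvegicus as the target, read by paw edema, with stated times of 30 min and 5 h, at a dose of 0.05 mmol/kg; a higher number here means more inhibition at the dose given (going by the name of the read-out), a lower number less inhibition:
Compound 1, `NS(=O)(=O)c1ccc(N2N=C(c3cccc(O)c3)C[C@H]2c2ccc(Cl)cc2)cc1`; compound 1 gives 51.8%.
Compound 2, `COc1ccc([C@@H]2CC(c3cccc(O)c3)=NN2c2ccc(S(N)(=O)=O)cc2)cc1`; compound 2 gives 62.9%.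
Compound 3, `NS(=O)(=O)c1ccc(N2N=C(c3cccc(O)c3)C[C@H]2c2ccccc2Cl)cc1`; compound 3 gives 70.3%.

Compound 3 holds the highest of the three numbers, though not clearly: a number 7.4 percentage points higher from compound 2 to compound 3 (within the scatter), whereas a number 18.5 percentage points higher from compound 1 to compound 3 (beyond the scatter).

Compound 4, `COc1ccc([C@@H]2CC(c3cccc(O)c3)=NN2c2ccc(S(N)(=O)=O)cc2)cc1OC`, is not yet measured. Its change from compound 3 is 3,4-dimethoxyphenyl in place of 2-chlorophenyl on a saturated ring carbon. Going by the values given here, no measured step makes exactly this exchange. The closest guides are a number 11.1 percentage points higher from compound 1 to compound 2 (beyond the scatter) and a number 7.4 percentage points higher from compound 2 to compound 3 (within the scatter), both small, and neither covers a second methoxy group. The step expected is therefore a number 7.3 percentage points lower from compound 3 to compound 4 (within the scatter), a modest drop or none beyond the scatter. Compound 4 is estimated at 63%, with a range from 50% to 76%.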

Compound 4, a percentage reported as inhibition, in the whole organism at one dose (the size of the read-out at that dose, not a potency): 66.7%
Beside the measured number, compound 4's estimate is 3.7 percentage points below it; measured number inside the range.
By their numbers in this assay, from the lowest: compound 1; then compounds 2, 4 and 3 (each within the scatter of the next).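

In this assay, the 3,4-dimethoxyphenyl group on this saturated ring carbon performs much like the groups already seen: a number 3.6 percentage points lower from compound 3 to compound 4 (within the scatter), and a number 3.8 percentage points higher from compound 2 to compound 4 (within the scatter). Neither replacing 2-chlorophenyl nor adding a second methoxy therefore shifts the result beyond the scatter, while a clear gap remains at a number 14.9 percentage points higher from compound 1 to compound 4 (beyond the scatter). Nothing available explains why these aryl groups give such similar results. Still open, on these data alone, is whether a dimethylamino group on this phenyl ring, or a pyridine ring in its place, would keep the inhibition at this level.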